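The source may hold more compounds than are shown below. What is called first, only, known or untested is meant among the compounds shown, and "the series" means these compounds.

Measured so far in a functional assay on UO-31 cells (Homo sapiens) for inhibition, read by sulforhodamine B assay, with a stated time of 48 h; a lower number here means a stronger inhibitor of growth, a higher number a weaker inhibitor of growth:
Compound 1 `O=C(Nc1cccc(-n2cc(-c3ccncc3)c(-c3ccc(Cl)c(O)c3)n2)c1)Nc1cccc(C(F)(F)F)c1`: > 32500 nM
Compound 2 `COc1cc(-c2nn(-c3cccc(NC(=O)c4cccc(C(F)(F)F)c4)c3)cc2-c2ccncc2)ccc1Cl`: > 50000 nM

Neither entry is a true number. Compound 1 reaches only a limit of the assay, > 32500 nM. On these data alone, compound 2 also reaches only a limit, > 50000 nM, so its real position on the scale is unknown.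

Compound 3 `COc1cc(-c2nn(-c3cccc(NC(=O)Nc4cccc(C(F)(F)F)c4)c3)cc2-c2ccncc2)ccc1Cl` is built from compound 2 by one change: (3-(trifluoromethyl)phenyl)amino in place of 3-(trifluoromethyl)phenyl on a carbonyl carbon. Going by the values given here, no measured pair shows what this change does in this assay, so any forecast is uncertain, and another limit would be no surprise. A modest move toward stronger growth inhibition is expected, estimated as an at least 2.0-fold lower number from compound 2 to compound 3 (0.30 log units; that floor lies within the scatter). For compound 3, the estimated value is 25000 nM, with an expected range of 5000 nM to 70000 nM.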

Compound 3, concentration for total growth inhibition: 3210 nM
Beside the measured number, compound 3's estimate is 7.8-fold (0.89 log units) above it, and the stated range ends above it.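

In this assay, (3-(trifluoromethyl)phenyl)amino in place of 3-(trifluoromethyl)phenyl on a carbonyl carbon gives an at least 15-fold lower number from compound 2 to compound 3 (1.19 log units; beyond the scatter), a clear gain even though the starting value is only a limit: the limit of > 50000 nM in this assay, at which 1 of the 3 values shown sits.

That group is not enough on its own, as compound 1 carries it too, and methyl in place of hydrogen on an oxygen on an aromatic ring gives an at least 10-fold lower number from compound 1 to compound 3 (1.00 log units; beyond the scatter), again starting from a limit: the limit of > 32500 nM in this assay, at which 1 of the 3 values shown sits.

Among these three compounds, only compound 3 has both the amino link and the methyl on the oxygen, and only compound 3 gives a true number.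

On these data alone, the real size of each step stays open, since each one starts from a limit. Also open, as far as these compounds go, is whether an ethyl in place of that methyl, or a methyl on the new amino nitrogen, would keep the growth inhibition.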